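A few compounds are considered here, and "the series" means these few. Any claim that something is new, unique, unknown or untested is made for them only; others in the source may bear on it.

The study compares four related compounds in a functional assay on cells (Cancer cell lines, Homo sapiens) for inhibition, with a stated time of 48 h; on this read-out higher numbers stand for weaker inhibition of growth and lower numbers for stronger inhibition of growth. Compound 1 `COc1cc2c(cc1C)NC(=O)/C2=C/c1c(Cl)n(C)c2cc(C)c(OC)cc12` gives 87100 nM in this assay, and compound 2 `COc1cc2c(cc1C)N(C)C(=O)/C2=C/c1c(Cl)n(C)c2cc(C)c(OC)cc12` gives 83200 nM. The change between them is methyl in place of hydrogen on an amide-type nitrogen in a ring, and it produces a 1.0-fold lower number from compound 1 to compound 2 (0.02 log units; within the scatter), so these two values cannot be told apart. Compound 3 `CN(C)c1ccc2[nH]c(Cl)c(/C=C3/C(=O)Nc4ccc(O)cc43)c2c1` is built on a different core; how that core differs from the core of compound 1 is not broken down here. In this assay compound 3 gives 20400 nM, a lower number than either of the other two measured compounds by more than the usual scatter. Compound 4 `CN(C)c1ccc2[nH]c(Cl)c(/C=C3/C(=O)N(C)c4ccc(O)cc43)c2c1` has not yet been measured. Its relation to compound 3 is methyl in place of hydrogen on an amide-type nitrogen in a ring, the same change as that between compound 1 and compound 2, at a place described in the same words. Because the earlier instance gave a 1.0-fold lower number from compound 1 to compound 2 (0.02 log units; within the scatter), the expected step is a 1.1-fold higher number from compound 3 to compound 4 (0.03 log units; within the scatter), essentially no movement. On that basis compound 4 is estimated at 22000 nM in this assay, with a plausible range from 8000 nM to 60000 nM.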

Compound 4, concentration for total growth inhibition: 20900 nM
Beside the measured number, compound 4's estimate is 1.1-fold (0.02 log units) above it; the measured number falls inside the stated range.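

In this assay, methyl in place of hydrogen on an amide-type nitrogen in a ring gives a 1.0-fold higher number from compound 3 to compound 4 (0.01 log units; within the scatter) and leaves compound 3 and compound 4 indistinguishable. Set beside the earlier instance, the change reads the same on both cores: the same change on two cores in this assay, a 1.0-fold lower number (0.02 log units; within the scatter) from compound 1 to compound 2 and a 1.0-fold higher number (0.01 log units; within the scatter) from compound 3 to compound 4, 1.1-fold (0.03 log units) apart, within the scatter of two such steps. Within the data shown here, this shows that, in this read-out, the change carried from the core of compound 1 to the core of compound 3 as a step too small to read, but it rests on only two pairs and shows nothing about other cores or other read-outs.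

Going by these compounds, both pairs put only methyl on that nitrogen, so it remains open whether a longer chain such as ethyl, or a chain ending in an amine or a carboxylic acid, would also leave the number unmoved. Also open, on these data alone, is whether an acetyl group on that nitrogen would behave as methyl does on either core.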